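Swapping Methoxy for Bromo on a Shared Core

The compounds below may be only part of what the source reports. "The series", "measured", "known", "first", "only" and "open" are said of these compounds alone.

Of the compounds shown here, three built on one core have been tested in a functional assay on A549 cells (Homo sapiens) for inhibition, read by MTT assay, with a stated time of 24 h (a higher number here means a weaker inhibitor, a lower number a stronger inhibitor), and a fourth awaits measurement. Compound 1 `O=C(O)C1=Cc2ccccc2OC1(OCc1cc(-c2ccc(F)cc2)no1)C(F)(F)F` carries a carboxylic acid; its result is a limit of the assay, > 150000 nM, rather than a number. Compound 2 `CCOC(=O)C1=Cc2ccccc2OC1(OCc1cc(-c2ccc(OC)cc2)no1)C(F)(F)F` is the ethyl ester with a 4-methoxyphenyl group; in this assay compound 2 also gives only the limit > 150000 nM. Compound 3 `CCOC(=O)C1=Cc2ccccc2OC1(OCc1cn(CC(=O)Nc2ccccc2Br)nn1)C(F)(F)F`, with a different side arm, likewise reaches only the limit > 150000 nM. So compound 2 stands exactly where the other two stand: at the ceiling of what this assay reports, a point summed up by the limit of > 150000 nM in this assay, at which 3 of the 3 values shown sit.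

Compound 4 `CCOC(=O)C1=Cc2ccccc2OC1(OCc1cc(-c2ccc(Br)cc2)no1)C(F)(F)F` differs from compound 2 in one place: bromo in place of methoxy on an aromatic carbon. No step between measured compounds is known, so nothing shown here tells whether this change strengthens or weakens inhibition. Since every measured value is a limit, the expectation for the step that the limit leaves unreadable from compound 2 to compound 4 is no movement beyond the scatter, and most likely another limit. Compound 4 is therefore estimated at 200000 nM in this assay, with a range from 60000 nM to 600000 nM.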

Compound 4, half-maximal inhibitory concentration: > 150000 nM
Compound 4: no number, only a limit; the forecaster's own chance of this, stated with the estimate: 80%; the middle value is on the limit's open side.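

Compound 4 gives only a limit of the assay, > 150000 nM. Compound 2 also gives only a limit, so no step from compound 2 to compound 4 can be read, and all the compounds sit at the same point: the limit of > 150000 nM in this assay, at which 4 of the 4 values shown sit.

The compounds shown leave open whether bromo and methoxy differ at all in this assay, and which structure on this shared core would give a measurable number.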